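Amide replacements on the ring nitrogen of the shared core

This account rests on a few compounds, and the source may have more. Where it says the series, first, only, none or still open, it means among the compounds named here.

Measured so far:
compound 1, `CC(C)CN1CCc2nc(C#Cc3ccccc3)sc2C1` — 650 nM
compound 2, `O=C(C1CC(F)C1)N1CCc2nc(C#Cc3ccccc3)sc2C1` — > 10000 nM

In an assay on HEK293 cells for negative allosteric modulation of metabotropic glutamate receptor 5 (Homo sapiens), read by FLIPR, with a stated time of 1 h (on this read-out lower numbers stand for stronger inhibition and higher numbers for weaker inhibition), compound 1 gives 650 nM. Compound 2 reaches only a limit of this assay, > 10000 nM, and so has no number of its own; this is the situation described by the limit of > 10000 nM in this assay, at which 1 of the 2 values shown sits. Among the compounds with values here, the one measured step, an at least 15-fold higher number from compound 1 to compound 2 (1.18 log units; beyond the scatter), goes from a basic amine on the ring nitrogen to an amide and is large.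

Compound 3, `O=C(c1cccc(Cl)c1)N1CCc2nc(C#Cc3ccccc3)sc2C1`, is not yet measured. It keeps the amide of compound 2 and differs from it in this way: 3-chlorophenyl in place of 3-fluorocyclobutyl on a carbonyl carbon. Within the data shown here, no measured step covers an exchange of this kind on the carbonyl carbon; the only step known concerns the amine-to-amide change, which compound 3 shares with compound 2. The expectation for an at least 2.5-fold lower number from compound 2 to compound 3 (0.39 log units; beyond the scatter) is therefore uncertain, leaning slightly toward a lower number but with a fair chance that this assay again reports only a limit. Compound 3 is estimated at 4000 nM, within 800 nM to 20000 nM.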

Compound 3, half-maximal inhibitory concentration: > 10000 nM
Compound 3: only a limit was reported; the forecaster's own chance of this, stated with the estimate: 40%; middle value at least 2.5-fold (0.39 log units) away from the limit.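

In this assay compound 3 gives > 10000 nM, a limit of the assay and not a number. Compound 2 also stands at a limit, so no step between compound 2 and compound 3 can be read: the limit of > 10000 nM in this assay, at which 2 of the 3 values shown sit.

Still open, on these data alone, is whether any amide on the ring nitrogen of the shared core gives a measurable number in this assay.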